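Halogen removal on the ester-linked aryl ring

The source may report more compounds than this note shows. Statements on the series, on what has been measured and on what is new or still open speak of the compounds shown alone.

Measured so far:
compound 1, `COC(=O)c1c(Br)cccc1OC(=O)COc1cc(O)c2c(=O)cc(-c3ccccc3)oc2c1`: 388000 nM
compound 2, `COC(=O)c1cccc(Cl)c1OC(=O)COc1cc(O)c2c(=O)cc(-c3ccccc3)oc2c1`: 366000 nM

In an ADME assay on cells (T-cell, Mus musculus, strain BALB/c) for cytotoxicity, read by MTT assay, with a stated time of 48 h (on this read-out lower numbers stand for higher toxicity in this test and higher numbers for lower toxicity in this test), compound 2 gives 366000 nM. Compound 2 stands alongside compound 1, which gives 388000 nM in this assay; the two numbers are separated only by a 1.1-fold lower number from compound 1 to compound 2 (0.03 log units; within the scatter), so neither can be set apart from the other.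

Compound 3, `COC(=O)c1ccccc1OC(=O)COc1cc(O)c2c(=O)cc(-c3ccccc3)oc2c1`, is the next member to be measured. It differs from compound 2 as follows: hydrogen in place of chloro on an aromatic carbon. For the measured compounds named here, only one step has been measured, the exchange of bromo for chloro on the same ring, and it moved the number by a 1.1-fold lower number from compound 1 to compound 2 (0.03 log units; within the scatter), within the scatter. Going by the values given here, no step from a halogen to hydrogen has been measured, so the bearing of the one known step on this change is indirect. Given that the sole halogen exchange left the number essentially unchanged, the step from compound 2 to compound 3 is expected to fall within the scatter as well, a 1.0-fold higher number from compound 2 to compound 3 (0.00 log units; within the scatter). Compound 3 is therefore estimated at 370000 nM, with a range from 200000 nM to 700000 nM.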

Compound 3, half-maximal cytotoxic concentration: 265000 nM
Compound 3: the middle estimate sits 1.4-fold (0.14 log units) above what was measured; measured number inside the range.
By their numbers in this assay, from the lowest: compounds 3, 2 and 1 (each within the scatter of the next).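

In this assay, hydrogen in place of chloro on the aromatic carbon gives a 1.4-fold lower number from compound 2 to compound 3 (0.14 log units; within the scatter) and hydrogen in place of bromo gives a 1.5-fold lower number from compound 1 to compound 3 (0.17 log units; within the scatter) as its counterpart. The 2-(methoxycarbonyl)phenyl ester of compound 3 therefore cannot be set apart from either halogenated ester, so neither halogen is needed to keep the read-out at this level among these three compounds. No measurement on hand explains this outcome.

Only chloro, bromo and hydrogen are compared on this ring, so a methoxy group or an amine on the same aromatic carbon remains an open case. Also open, on these data alone, is whether a carboxylic acid in place of the methoxycarbonyl group would carry the number beyond the scatter.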